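This account rests on a few compounds, and the source may have more. Where it says the series, first, only, none or still open, it means among the compounds named here.

Of the compounds shown here, three from this series have been tested in an ADME assay on HaCaT cells (Homo sapiens) for antiproliferative activity, read by MTT assay, with a stated time of 48 h; a lower number here means a stronger inhibitor, a higher number a weaker inhibitor. Compound 1 `O=C(/C=C\Nc1ccc(Cl)cc1)c1cn(-c2ccccc2)nc1-c1ccc(F)cc1` gives 21300 nM. Compound 3 `COc1ccc(N/C=C\C(=O)c2cn(-c3ccccc3)nc2-c2ccc(F)cc2)cc1` gives 19600 nM. For compound 2 `O=C(/C=C\Nc1ccc(C(F)(F)F)cc1)c1cn(-c2ccccc2)nc1-c1ccc(F)cc1` only a limit of the assay is reported, > 50000 nM. Among the two real numbers, compound 1 stands highest, with compound 3 nearest at a 1.1-fold lower number from compound 1 to compound 3 (0.04 log units; within the scatter). The step of an at least 2.3-fold higher number from compound 1 to compound 2 (0.37 log units; beyond the scatter) moves past the limit described by the limit of > 50000 nM in this assay, at which 1 of the 3 values shown sits, while an at least 2.5-fold lower number from compound 2 to compound 3 (0.40 log units; beyond the scatter) brings the value back to a real number.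

Compound 4 `O=C(/C=C\Nc1ccc(Cl)cc1)c1cn(-c2ccccc2)nc1-c1ccc(Cl)cc1` differs from compound 1 at the other end of the shared core: chloro in place of fluoro on an aromatic carbon. Among the measured compounds shown here, none of the measured steps touches this position; they all swap the group on the ring attached to the nitrogen of the chain, and there chloro and methoxy behaved alike while trifluoromethyl weakened activity. For the measured compounds named here, with no direct precedent, the expected step of a 1.1-fold lower number from compound 1 to compound 4 (0.03 log units; within the scatter) is small. The estimate for compound 4 in this assay is 20000 nM, ranging from 8000 nM to 50000 nM.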

Compound 4, half-maximal inhibitory concentration: 23400 nM
Compound 4: middle estimate off by 1.2-fold (0.07 log units), on the low side, and the stated range covers the measured number.
By their numbers in this assay, from the lowest: compounds 3, 1 and 4 (each within the scatter of the next). At a limit, above all of these: compound 2.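

In this assay, the change from 4-fluorophenyl to 4-chlorophenyl gives a 1.1-fold higher number from compound 1 to compound 4 (0.04 log units; within the scatter) and is the first step shown at this end of the shared core. Exchanging one halogen for the other on this ring therefore leaves compounds 1 and 4 within the scatter of each other, so this pair gives no sign that the choice between fluoro and chloro matters here. Nothing shown bears on why these two numbers sit so close together.

This single pair tests only two halogens at this place, so it cannot say whether the position tolerates any change or only this one. An amine, a carboxylic acid or a longer chain on this ring could still move the number well beyond the scatter, in either direction.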